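This account rests on a few compounds, and the source may have more. Where it says the series, first, only, none or still open, it means among the compounds named here.

Working notes on the series. Compound 1 `C/C=C(\C)C1=C(CO)[C@H](O)[C@H]2O[C@H]2C1=O` and compound 2 `C/C=C/C1=C(CO)[C@H](OC)[C@H]2O[C@H]2C1=O` share a core and both have been tested in a functional assay on SKW 6.4 cells (Homo sapiens); on this read-out higher numbers stand for an effect only at larger amounts of compound and lower numbers for an effect already at smaller amounts. For compound 1 the result in this assay is a limit and not a number, namely > 80 uM. For compound 2 the result in this assay is likewise a limit, namely > 80 uM. Compound 1 therefore stands at the edge of what the measurements can report, and the limit of > 80 uM in this assay, at which 2 of the 2 values shown sit, is the only thing that can be said of where the two values sit. Within the data shown here, no step between measured compounds is available, so the series offers no measured change to compare against.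

Compound 3 `O=C1C=C(CO)[C@H](O)[C@H]2O[C@@H]12` has not yet been measured in this assay. It differs from compound 1 in one place: hydrogen in place of 1-methylprop-1-en-1-yl on a double-bonded ring carbon. The expected step that the limit leaves unreadable from compound 1 to compound 3 is taken as none beyond the scatter, because the limit of > 80 uM in this assay, at which 2 of the 2 values shown sit, already places compound 1 at the limit and leaves no measured room for the number to move. For compound 3 the estimate in this assay is 120 uM, with a range from 40 uM to 400 uM, and a limit rather than a number is the more likely report.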

Compound 3, concentration for half-maximal effect: > 80 uM
Compound 3: a limit, no number; the forecaster's own chance of this, stated with the estimate: 80%; the middle value does not contradict the limit.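

Compound 1 and compound 3 both give only a limit in this assay, so the step between them, hydrogen in place of 1-methylprop-1-en-1-yl, cannot be read: the limit of > 80 uM in this assay, at which 3 of the 3 values shown sit.

The compounds shown leave open whether any compound on the shared core gives a number in this assay, and what the substituent on the double-bonded ring carbon contributes.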